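The source may hold more compounds than are shown below. What is called first, only, known or untested is meant among the compounds shown, and "the series" means these compounds.

Among the compounds with values here, in a functional assay on MCF7 cells (Homo sapiens) for cytotoxicity, read by MTT assay, with a stated time of 68 h (on this read-out higher numbers stand for weaker inhibition and lower numbers for stronger inhibition), compound 1 `O=C(/C=C/c1cccc(OCc2ccccc2)c1)c1ccc(Cl)cc1` gives 24800 nM, the higher of the two numbers so far. Compound 2 `COc1cc(C2Oc3cc(/C=C/C(=O)c4ccccc4O)ccc3OC2CO)ccc1O` gives 12100 nM, and that gap lies beyond the usual scatter. Compound 3 `O=C(/C=C/c1cccc(OCc2ccccc2)c1)c1cccc(Br)c1` keeps the core of compound 1 but has 3-bromophenyl in place of 4-chlorophenyl on a carbonyl carbon. Within the data shown here, no measured pair shows what such a swap does, so no change beyond the scatter is expected in this assay. The estimate amounts to an expected step of a 1.1-fold lower number from compound 1 to compound 3 (0.05 log units; within the scatter). The estimated value for compound 3 is 22000 nM, with an expected range of 8000 nM to 50000 nM.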

Compound 3, half-maximal inhibitory concentration: 7900 nM
For compound 3 the middle estimate is 2.8-fold (0.44 log units) above the measured one; measured number below the stated range.
By their numbers in this assay, from the lowest: compounds 3 and 2 (each within the scatter of the next); then compound 1.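

In this assay the swap of 4-chlorophenyl for 3-bromophenyl on a carbonyl carbon gives a 3.1-fold lower number from compound 1 to compound 3 (0.50 log units; beyond the scatter) and thus shows that the number responds to the ring at this place on the shared core. The two rings have the same count of heavy atoms, yet the step lies beyond the usual scatter. Nothing available explains this step.

The halogen and its place on the ring change together, so their shares in the step remain unseparated; 4-bromophenyl or 3-chlorophenyl would separate them. Going by these compounds, how an amine or a carboxylic acid on this ring would behave also remains open.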